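The source may report more compounds than this note shows. Statements on the series, on what has been measured and on what is new or still open speak of the compounds shown alone.

Compound 1 `O=C1NC(=O)N(/N=C/c2ccc(-c3ccc(Cl)cc3)o2)C1O`, compound 2 `N#Cc1ccc(-c2ccc(/C=N/N3C(=O)NC(=O)C3O)o2)cc1` and compound 3 `CC(=O)Nc1ccc(-c2ccc(/C=N/N3C(=O)NC(=O)C3O)o2)cc1` share one core and differ in the group on one aromatic carbon. In a functional assay on the whole organism for activation, with Mus musculus as the target, with a stated time of 60 min (a lower number here means that less compound is needed, a higher number that more compound is needed for the effect), compound 3, with acetamido, gives > 1000 mg/kg, which is a limit and not a number. Compound 1, with chloro, gives > 1000 mg/kg, which is also a limit. Among the compounds with values here, compound 2, with cyano, gives 156 mg/kg, the only actual number so far. Compound 3 therefore sits at the limit of > 1000 mg/kg in this assay, at which 2 of the 3 values shown sit.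

Compound 4 `Nc1ccc(-c2ccc(/C=N/N3C(=O)NC(=O)C3O)o2)cc1` differs from compound 3 by hydrogen in place of acetyl on a nitrogen on an aromatic ring, so acetamido becomes amino. Within the data shown here, no measured step makes this exact change. The nearest are an at least 6.4-fold lower number from compound 1 to compound 2 (0.80 log units; beyond the scatter) and an at least 6.4-fold higher number from compound 2 to compound 3 (0.80 log units; beyond the scatter), which show that swapping the group at this place can matter, while a step that the two limits leave unreadable from compound 1 to compound 3 says nothing about size. A modest move towards a lower number seems reasonable, though another limit is quite possible. The expected change is an at least 2.2-fold lower number from compound 3 to compound 4 (0.34 log units; beyond the scatter). For compound 4, the estimated value is 450 mg/kg, with an expected range of 110 mg/kg to 1500 mg/kg.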

Compound 4, dose for half-maximal effect: > 1000 mg/kg
Compound 4 was reported as a limit; the forecaster's own chance of this, stated with the estimate: 45%; at least 2.2-fold (0.34 log units) between middle value and limit.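

Taking the acetyl off the nitrogen does not bring a readable value in this assay: compound 4, with amino, gives > 1000 mg/kg, which is a limit and not a number. The steps to compound 4 from compound 1 and from compound 3 join two limits and cannot be read. The one readable step is an at least 6.4-fold higher number from compound 2 to compound 4 (0.80 log units; beyond the scatter), so amino, like chloro and acetamido, needs more compound than cyano, and cyano remains the only group here with an actual number: the limit of > 1000 mg/kg in this assay, at which 3 of the 4 values shown sit.

On these data alone, the order among compound 1, compound 3 and compound 4 stays open, as all three end at a limit. Also open, as far as these compounds go, is whether cyano stands alone at this place, or whether a group such as trifluoromethyl, a carboxylic acid or a methyl ester would also give an actual number.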